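The compounds below may be only part of what the source reports. "The series", "measured", "known", "first", "only" and "open" are said of these compounds alone.

In a functional assay on blood (Homo sapiens), with a stated time of 60 min, in the presence of a further agent that is not named here (a higher number here means that more compound is needed for the effect, a lower number that less compound is needed), compound 1 `Nc1ccccc1NC(=O)C1(S(=O)(=O)c2ccc(Oc3ccc(OC(F)(F)F)cc3)cc2)CCC2(CCNCC2)C1` gives 900 nM. Compound 2 `Nc1ccc(F)cc1NC(=O)C1(S(=O)(=O)c2ccc(Oc3ccc(OC(F)(F)F)cc3)cc2)CCC2(CCNCC2)C1` reads > 15000 nM, which is a limit of the assay and not a number. Compound 3 `CC(=O)Nc1ccc(Oc2ccc(S(=O)(=O)C3(C(=O)Nc4ccccc4N)CCC4(CCNCC4)C3)cc2)cc1` gives 3700 nM, the higher of the two actual numbers, and compound 1 is its nearest neighbour.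

Compound 4 `Nc1ccccc1NC(=O)C1(S(=O)(=O)c2ccc(NC3CCCCC3)cc2)CCC2(CCNCC2)C1` carries cyclohexylamino in place of 4-acetamidophenoxy on an aromatic carbon. Within the data shown here, the closest precedent is a 4.1-fold higher number from compound 1 to compound 3 (0.61 log units; beyond the scatter), a modest step from acetamido in place of trifluoromethoxy on an aromatic carbon. The large step of an at least 16-fold higher number from compound 1 to compound 2 (1.22 log units; beyond the scatter) comes from fluoro in place of hydrogen, a different change, and is set aside. Among the measured compounds shown here, no measured step removes the outer aromatic ring, so the direction is poorly supported.

In this assay a slightly lower number is expected, with no step beyond the scatter as the central case, though a modest step either way remains possible. The estimate corresponds to a 1.5-fold lower number from compound 3 to compound 4 (0.17 log units; within the scatter). For compound 4 the estimated value is 2500 nM, with an expected range of 600 nM to 10000 nM.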

Compound 4, half-maximal effective concentration: <= 400 nM
Compound 4 ended at the assay's limit; the forecaster's own chance of this, stated with the estimate: 10%; at least 6.2-fold (0.79 log units) between middle value and limit.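

Notes on the position on the aromatic carbon para to a large group: in this assay, cyclohexylamino in place of 4-acetamidophenoxy gives an at least 9.2-fold lower number from compound 3 to compound 4 (0.96 log units; beyond the scatter), and cyclohexylamino in place of 4-(trifluoromethoxy)phenoxy gives an at least 2.2-fold lower number from compound 1 to compound 4 (0.35 log units; beyond the scatter). Compounds 1 and 3 both keep an outer aromatic ring at this position, so they could not show that a non-aromatic ring is tolerated here; compound 4 shows that it is, and that it can read lower than either. Compound 4 stands at a limit of the assay and not at a number: the limit of <= 400 nM in this assay, at which 1 of the 4 values shown sits.

The full size of both steps therefore stays unknown, and the compounds shown do not separate the loss of the aromatic ring from the change of the linking atom. From the compounds shown here alone, what a cyclohexyloxy group, or a longer alkyl chain on the same nitrogen, would give remains open.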